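The source may hold more compounds than are shown below. What is called first, only, known or untested is meant among the compounds shown, and "the series" means these compounds.

The measured compounds:
compound 1, `CCCc1nc2cc(-c3nc4cc(-c5nc6cc(-c7ccccc7)ccc6[nH]5)ccc4[nH]3)ccc2[nH]1`, in a functional assay on RPMI 8402 cells (Homo sapiens) for cytotoxicity (a lower number here means a stronger inhibitor, a higher number a weaker inhibitor), gives 60 nM.
compound 2, `Clc1ccc(-c2ccc3[nH]c(-c4ccc5[nH]c(-c6ccc7[nH]cnc7c6)nc5c4)nc3c2)cc1`, in this assay gives 90 nM.
compound 3, `CCc1nc2cc(-c3nc4cc(-c5nc6cc(-c7ccccc7)ccc6[nH]5)ccc4[nH]3)ccc2[nH]1`, in this assay gives 110 nM.

Compound 2 stands second highest of these three numbers. Its nearest neighbour is compound 3 and its furthest is compound 1, and in both cases the gap lies within the usual scatter, so the three values cannot be told apart with any confidence.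

Compound 4, `c1ccc2cc(-c3ccc4[nH]c(-c5ccc6[nH]c(-c7ccc8[nH]cnc8c7)nc6c5)nc4c3)ccc2c1`, has not been measured. It differs from compound 2 in one place: naphthalen-2-yl in place of 4-chlorophenyl on an aromatic carbon.

Among the measured compounds a single step differs in one place: a 1.8-fold higher number from compound 1 to compound 3 (0.26 log units; within the scatter). That step alters a saturated chain and not the aromatic carbon where compound 4 differs from compound 2, so it bears on the present change only as a sign that a single alteration in this series has so far stayed within the scatter. For the measured compounds named here, no measured pair isolates an exchange of the aryl group itself.

Compound 4 is therefore expected to stay close to compound 2, with an expected step of no change at the digits printed from compound 2 to compound 4 (within the scatter), not beyond the scatter. The estimate for compound 4 in this assay is 90 nM, expected to fall between 40 nM and 200 nM.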

Compound 4, half-maximal inhibitory concentration: 80 nM
Estimate against measurement, compound 4: 1.1-fold (0.05 log units) above, within the range that was stated.
By their numbers in this assay, from the lowest: compounds 1, 4, 2 and 3 (each within the scatter of the next).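

In this assay, for the compounds shown here, the exchange of 4-chlorophenyl for naphthalen-2-yl gives a 1.1-fold lower number from compound 2 to compound 4 (0.05 log units; within the scatter), and this is the first measured pair in which the aryl group itself is exchanged on this aromatic carbon. The position therefore takes 2 six-membered aromatic rings of carbon only, with 10 heavy atoms and no chlorine, in place of one such ring bearing chlorine, with 7 heavy atoms, and the assay cannot tell the two compounds apart. No measurement shown here speaks to why these two groups read alike.

Both groups are built on aromatic rings of carbon only and have no hydrogen-bond donors or acceptors, so the compounds shown leave open whether an amine, a carboxylic acid or a pyridine ring on this aromatic carbon would also stay within the scatter of compound 2. They also leave open whether naphthalen-2-yl and 4-chlorophenyl would read alike on a core that carries a saturated chain like that of compound 1 or a longer chain.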